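Moving the ring substituents in an antiproliferative amide series

A few compounds are considered here, and "the series" means these few. Any claim that something is new, unique, unknown or untested is made for them only; others in the source may bear on it.

Measured compounds:
compound 1, `CN1CCN(c2ccc(Nc3nc(-c4cccc(NC(=O)c5cccc(F)c5)c4)sc3C(N)=O)cc2)CC1`, 2.78%
compound 2, `CN1CCN(c2ccc(Nc3nc(-c4cccc(NC(=O)c5ccccc5F)c4)sc3C(N)=O)cc2)CC1`, 97.3%

In a functional assay on Raji cells (Homo sapiens) for antiproliferative activity, read by CCK-8 assay, with a stated time of 72 h, tested at 40 uM (a lower number here means less inhibition, a higher number more inhibition at the concentration tested (going by the name of the read-out)), compound 2 stands highest of the two numbers; its nearest neighbour is compound 1, which gives 2.78%. Within the data shown here, the single measured step, a number 94.5 percentage points higher from compound 1 to compound 2 (beyond the scatter), shows that where the fluorine sits on this ring decides almost the whole read-out. Compound 3, `CN1CCN(c2ccc(Nc3nc(-c4cccc(NC(=O)c5ccc(F)c(Cl)c5)c4)sc3C(N)=O)cc2)CC1`, changes that ring again: 3-chloro-4-fluorophenyl in place of 2-fluorophenyl on a carbonyl carbon. Compound 3 carries no substituent at the 2-position of the ring and instead bears a chlorine at the 3-position, the position where compound 1 carries its fluorine, together with a fluorine at the 4-position. Among the measured compounds shown here, no step covering a 3-chloro-4-fluorophenyl is known, so the size of the change rests on the one step. Compound 3 is expected to fall well below compound 2, with a number 72.3 percentage points lower from compound 2 to compound 3 (beyond the scatter), and is estimated at 25% in this assay, within a range of 0% to 85%.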

Compound 3, a percentage reported as inhibition, at one concentration (the size of the read-out at that concentration, not a potency): 94.4%
The estimate for compound 3 lay 69.4 percentage points below the measured number; measured number above the stated range.
By their numbers in this assay, from the lowest: compound 1; then compounds 3 and 2 (each within the scatter of the next).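

In this assay, among these compounds, there is a number 2.9 percentage points lower from compound 2 to compound 3 (within the scatter) and so the 2-fluorophenyl is not the only group on this carbonyl carbon that gives a high read-out; the two groups cannot be told apart here. this assay also shows a number 91.6 percentage points higher from compound 1 to compound 3 (beyond the scatter) and so, among the three groups, the low number stays with the 3-fluorophenyl alone. Nothing given here accounts for these differences.

The compounds shown leave open whether the chlorine or the fluorine of the 3-chloro-4-fluorophenyl carries the change, which a 4-fluorophenyl or a 3-chlorophenyl on the same carbonyl carbon would separate. They also leave open how a ring bearing a methoxy group or an amine would read and, with a single tested concentration, how compound 2 and compound 3 compare in potency.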